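This account rests on a few compounds, and the source may have more. Where it says the series, first, only, none or still open, it means among the compounds named here.

Working notes on the series.

For the measured compounds named here, in a functional assay on HT-1080 cells (Homo sapiens), read by transwell migration, with a stated time of 24 h, tested at 1 uM (a higher number here means a weaker effect of the compound at the concentration tested, a lower number a stronger effect), compound 3 `CC(=O)NCc1ccc2oc(=O)c(C(=O)Oc3cccc(Cl)c3)cc2c1` gives 36.6%, the lowest of the three numbers so far. The nearest is compound 1 `CC(=O)OCc1ccc2oc(=O)c(C(=O)Oc3cccc(Cl)c3)cc2c1`, which gives 49.1%; the furthest is compound 2 `NCc1ccc2oc(=O)c(C(=O)Oc3cccc(Cl)c3)cc2c1`, which gives 86.6%. Both steps into compound 3 are beyond the scatter: a number 12.5 percentage points lower from compound 1 to compound 3 (beyond the scatter) and a number 50 percentage points lower from compound 2 to compound 3 (beyond the scatter), with a number 37.5 percentage points higher from compound 1 to compound 2 (beyond the scatter) between the other two.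

The next compound is compound 4 `O=C(Oc1cccc(Cl)c1)c1cc2ccccc2oc1=O`. Change from compound 3: hydrogen in place of acetamidomethyl on an aromatic carbon

Going by the values given here, no measured step removes this group outright; the steps that bear on it are those that exchange one group for another at the same place, and they show that the identity of the group moves the read-out from modest to large. With the group gone altogether, the result is undecided between the two extremes seen so far, so a step upward from compound 3 of uncertain size is expected, and a wide range is set.

Compound 4 is expected to give 58%, with a range from 35% to 85%. The estimated step is a number 21.4 percentage points higher from compound 3 to compound 4 (beyond the scatter).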

Compound 4, a percentage reported as activity, at one concentration (the size of the read-out at that concentration, not a potency): 45.5%
The estimate for compound 4 lay 12.5 percentage points above the measured number; measured number inside the range.
By their numbers in this assay, from the lowest: compounds 3, 4 and 1 (each within the scatter of the next, the first and the last beyond it); then compound 2.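

In this assay the compound with hydrogen on this aromatic carbon gives the series its baseline, and two of the groups cannot be told apart from that hydrogen (a number 8.9 percentage points higher from compound 3 to compound 4 (within the scatter); a number 3.6 percentage points lower from compound 1 to compound 4 (within the scatter)). Aminomethyl alone stands apart from hydrogen (a number 41.1 percentage points lower from compound 2 to compound 4 (beyond the scatter)), so the large spread among the earlier compounds comes from compound 2 and not from any gain with acetamidomethyl or acetoxymethyl over hydrogen. Nothing at hand gives a cause for this difference.

Open, as far as these compounds go, is whether hydroxymethyl or a carboxylic acid on this carbon would stay with hydrogen or move with aminomethyl. Also open, from the compounds shown here alone, is whether a dimethylaminomethyl group or a longer chain carrying a terminal amine would keep the read-out of compound 2 (86.6%).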